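The source may report more compounds than this note shows. Statements on the series, on what has been measured and on what is new or still open speak of the compounds shown alone.

Measured in an assay on isolated protein for inhibition of cathepsin S (Homo sapiens), tested at 1 uM (on this read-out higher numbers stand for more inhibition at the one concentration tested (going by the name of the read-out) and lower numbers for less inhibition), so far are three compounds: compound 1, `COc1cccc2[nH]c(C(=O)N[C@@H](CC(C)C)C(=O)N[C@H](C#N)C[C@@H]3CCCNC3=O)cc12`, which gives 73%; compound 2, `CC(C)C[C@H](NC(=O)c1cc2c(OC(F)(F)F)cccc2[nH]1)C(=O)N[C@H](C#N)C[C@@H]1CCCNC1=O`, which gives 67%; and compound 3, `COc1cccc2[nH]c(C(=O)N[C@@H](CC(C)C)C(=O)N[C@H](C#N)C[C@@H]3CCNC3=O)cc12`, which gives 78%.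

Compound 2 has the lowest of the three numbers. Its nearest neighbour is compound 1, with a number 6 percentage points lower from compound 1 to compound 2 (within the scatter); compound 3 lies further off, with a gap to compound 2 that is beyond the scatter.

Compound 4, `CCOc1cccc2[nH]c(C(=O)N[C@@H](CC(C)C)C(=O)N[C@H](C#N)C[C@@H]3CCCNC3=O)cc12`, differs from compound 2 at the group on the oxygen on the aromatic ring: ethyl in place of trifluoromethyl on an oxygen on an aromatic ring. Within the data shown here, the only measured step at that position is the one from methyl to trifluoromethyl, a number 6 percentage points lower from compound 1 to compound 2 (within the scatter), which stayed within the scatter. Reversing the direction of that step with a different alkyl group, the account expects for compound 4 a change in this assay of about a number 5 percentage points higher from compound 2 to compound 4 (within the scatter), not beyond the scatter. Compound 4 is therefore estimated at 72%, with a range from 58% to 84%.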

Compound 4, a percentage reported as inhibition, at one concentration (the size of the read-out at that concentration, not a potency): 74%
Estimate against measurement, compound 4: 2 percentage points below; low and high end bracket the measured number.
By their numbers in this assay, from the lowest: compounds 2, 1, 4 and 3 (each within the scatter of the next, the first and the last beyond it).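

In this assay, the two new steps, a number 7 percentage points higher from compound 2 to compound 4 (within the scatter) and a number 1 percentage points higher from compound 1 to compound 4 (within the scatter), extend the comparison at this oxygen to ethyl, and both stay within the scatter. Compounds 1, 2 and 4, carrying methyl, trifluoromethyl and ethyl, therefore cannot be told apart in this assay. No evidence is available that bears on this result.

Still open, on these data alone, is whether a longer chain or an amine on that oxygen would take the number beyond the scatter. As far as these compounds go, it is also open whether ethyl gives a comparable number alongside the 2-oxopyrrolidin-3-yl group of compound 3.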